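Swapping the aryl group on a benzimidazole-piperidine scaffold

The source may hold more compounds than are shown below. What is called first, only, known or untested is meant among the compounds shown, and "the series" means these compounds.

Measured so far:
compound 1, `CC(=O)Nc1cccc(C2CCN(CCCn3c(-c4ccccc4Cl)nc4ccccc43)CC2)c1`, in an assay for displacement of a labelled ligand from melanin-concentrating hormone receptor 1 (Homo sapiens), read by fluorescence (on this read-out lower numbers stand for stronger inhibition and higher numbers for weaker inhibition), gives 10 nM
compound 2, `CC(=O)Nc1cccc(C2CCN(CCCn3c(-c4ccccc4C(F)(F)F)nc4ccccc43)CC2)c1`, in this assay gives 50 nM
compound 3, `COc1ccccc1-c1nc2ccccc2n1CCCN1CCC(c2cccc(NC(C)=O)c2)CC1`, in this assay gives 747 nM

Compound 3 stands highest of the three numbers, so it is the weakest binder here: the step of a 15-fold higher number from compound 2 to compound 3 (1.17 log units; beyond the scatter) and the step of a 75-fold higher number from compound 1 to compound 3 (1.87 log units; beyond the scatter) both go well beyond the scatter. Between the two stronger compounds, the step of a 5.0-fold higher number from compound 1 to compound 2 (0.70 log units; beyond the scatter) is smaller.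

Compound 4, `CC(=O)Nc1cccc(C2CCN(CCCn3c(-c4ccc(C#N)cc4)nc4ccccc43)CC2)c1`, has not yet been measured. It differs from compound 3 by a single change: 4-cyanophenyl in place of 2-methoxyphenyl on an aromatic carbon.

Going by the values given here, two measured steps bear on this change, since both also replace the methoxy-bearing aryl group on the same carbon of the shared core: a 75-fold higher number from compound 1 to compound 3 (1.87 log units; beyond the scatter) and a 15-fold higher number from compound 2 to compound 3 (1.17 log units; beyond the scatter). Read in reverse, each says that taking the 2-methoxyphenyl away from compound 3 gave a much lower number. Among the compounds with values here, no measured step, however, places a nitrile on this aryl group, nor moves the substituent to the position it holds in the 4-cyanophenyl, so the size of the gain is uncertain. A step down from compound 3 is nevertheless expected, estimated at a 3.7-fold lower number from compound 3 to compound 4 (0.57 log units; beyond the scatter).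

Compound 4 is therefore expected to give about 200 nM in this assay, with a range from 40 nM to 1000 nM.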

Compound 4, half-maximal inhibitory concentration: 16 nM
Beside the measured number, compound 4's estimate is 13-fold (1.10 log units) above it; the whole stated range lies above it.
By their numbers in this assay, from the lowest: compounds 1 and 4 (each within the scatter of the next); then compound 2; then compound 3.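

In this assay the step to 4-cyanophenyl on the aromatic carbon between two ring nitrogen atoms gives a 47-fold lower number from compound 3 to compound 4 (1.67 log units; beyond the scatter) even though the group that leaves and the group that enters have the same counts of heavy atoms and hydrogen-bond acceptors, so those counts alone do not separate a weak compound from a strong one in this set. The earlier compounds shown here carried only 2-chlorophenyl, 2-(trifluoromethyl)phenyl or 2-methoxyphenyl here, and compound 4 shows that a ring substituted elsewhere can also bind well: there is a 3.1-fold lower number from compound 2 to compound 4 (0.49 log units; beyond the scatter) and also a 1.6-fold higher number from compound 1 to compound 4 (0.20 log units; within the scatter) so compound 4 cannot be told apart from compound 1 in this assay. No measurement offered here explains why the numbers move as they do.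

On these data alone, this change swaps both the substituent and its place on the ring, so the share of each remains open, and 2-cyanophenyl or 4-methoxyphenyl would be needed to pull them apart. Also open, as far as these compounds go, is how plain phenyl, or an amine or a carboxylic acid in place of the nitrile on the 4-substituted ring, would fare in this assay.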